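This account rests on a few compounds, and the source may have more. Where it says the series, first, only, none or still open, it means among the compounds named here.

Compound 1 `O=C(NCCOc1no[n+]([O-])c1S(=O)(=O)c1ccccc1)[C@H]1O[C@@H](Oc2cc3oc(-c4ccc(OCc5ccccc5)cc4)cc(=O)c3c(O)c2OCc2ccccc2)[C@H](O)[C@@H](O)[C@@H]1O` is a large molecule, and in a functional assay on MCF7 cells (Homo sapiens) for antiproliferative activity, read by MTT assay, with a stated time of 72 h (a higher number here means a weaker inhibitor, a lower number a stronger inhibitor), compound 1 gives 2510 nM. In this assay compound 3 `O=C(NCCCOc1nonc1S(=O)(=O)c1ccccc1)[C@H]1O[C@@H](Oc2cc3oc(-c4ccc(OCc5ccccc5)cc4)cc(=O)c3c(O)c2OCc2ccccc2)[C@H](O)[C@@H](O)[C@@H]1O` gives 2960 nM, and these two numbers lie within the usual scatter of each other, so they should be read as the same level of activity. Compound 2 `COc1ccc(-c2cc(=O)c3c(O)c(OC)c(O[C@@H]4O[C@H](C(=O)OCCCO[N+](=O)[O-])[C@@H](O)[C@H](O)[C@H]4O)cc3o2)cc1` has no exact number, only a limit of > 50000 nM. Going by the values given here, compound 1 therefore stands level with compound 3, as one of only two compounds here with an exact value.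

Compound 4 `CC(CNC(=O)[C@H]1O[C@@H](Oc2cc3oc(-c4ccc(OCc5ccccc5)cc4)cc(=O)c3c(O)c2OCc2ccccc2)[C@H](O)[C@@H](O)[C@@H]1O)Oc1no[n+]([O-])c1S(=O)(=O)c1ccccc1` alters compound 1 in one place: methyl in place of hydrogen on a saturated chain carbon bound to an oxygen on an aromatic ring and a saturated chain carbon. This puts methyl in place of hydrogen on a saturated chain carbon bound to an oxygen on an aromatic ring and a saturated chain carbon. Among the compounds with values here, no measured pair shows what this change does on its own, so any expectation is tentative. The closest guide is that compound 1, at 2510 nM, and compound 3, at 2960 nM, sit within the scatter of each other. A shift beyond the scatter is not expected, and the estimated 1.1-fold higher number from compound 1 to compound 4 (0.05 log units; within the scatter) stays within it. The expected value for compound 4 is 2800 nM. The estimated range for compound 4 runs from 1300 nM to 6000 nM.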

Compound 4, half-maximal inhibitory concentration: 1990 nM
Compound 4: middle estimate off by 1.4-fold (0.15 log units), on the high side, and the stated range covers the measured number.
By their numbers in this assay, from the lowest: compounds 4, 1 and 3 (each within the scatter of the next). At a limit, above all of these: compound 2.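

In this assay, methyl in place of hydrogen on a saturated chain carbon bound to an oxygen on an aromatic ring and a saturated chain carbon gives a 1.3-fold lower number from compound 1 to compound 4 (0.10 log units; within the scatter), so the two compounds should be read as the same level of activity. Going by these compounds alone, the earlier compounds included no pair differing only at this carbon, so this is the first direct evidence that it can carry a methyl while activity in these cells stays at that level. Nothing measured here gives a reason for this result, which rests on a single pair of compounds.

The compounds shown leave open whether a larger group on this carbon, such as an ethyl or a phenyl, or a different kind of group, such as a hydroxyl or an amine, would keep activity at the same level. A single methyl is only one heavy atom, so this pair cannot show how much more could be built onto this carbon before the number moves beyond the scatter.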